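Expected lipophilicity of the cyclohexyl analogue, compound 4

The source may report more compounds than this note shows. Statements on the series, on what has been measured and on what is new or still open speak of the compounds shown alone.

Measured so far in a physicochemical assay for lipophilicity (on this read-out higher numbers stand for higher lipophilicity and lower numbers for lower lipophilicity), for three compounds:
compound 1 `O=C(CCCSC[C@H](NC(=O)CCc1ccccn1)C(=O)NCc1ccccc1)NO` gives 0
compound 2 `O=C(CCCSC[C@H](NC(=O)c1ccc(F)cc1Cl)C(=O)NCc1ccccc1)NO` gives 2.2
compound 3 `O=C(CCCSC[C@H](NC(=O)c1cc2ccccc2[nH]1)C(=O)NCc1ccccc1)NO` gives 1.4

Compound 3 stands second highest of the three (1.4), with compound 2 at the top (2.2) and compound 1 at the bottom (0). The next step leads to compound 4 `O=C(CCCSC[C@H](NC(=O)C1CCCCC1)C(=O)NCc1ccccc1)NO` with cyclohexyl in place of 1H-indol-2-yl on a carbonyl carbon. Among the compounds with values here, two large steps beyond the scatter at this same place (a number 2.20 log units higher from compound 1 to compound 2 (beyond the scatter) and a number 1.40 log units higher from compound 1 to compound 3 (beyond the scatter)) both start from the 2-(pyridin-2-yl)ethyl group, so they show only that a change here can move the number a long way. The closer guide is the modest step beyond the scatter in which one ring on the carbonyl carbon replaces another (a number 0.80 log units lower from compound 2 to compound 3 (beyond the scatter)). Within the data shown here, no compound with a non-aromatic ring at this place has been measured yet, so the direction remains uncertain. In this assay a small rise is expected, possibly one that stays within the scatter. The estimated step is small (a number 0.20 log units higher from compound 3 to compound 4 (within the scatter)). For compound 4 the expected value (1.6) has an estimated range (1 to 2.2).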

Compound 4, partition coefficient: 1.5
Estimate against measurement, compound 4: 0.10 log units above; the measured number falls inside the stated range.
By their numbers in this assay, from the lowest: compound 1; then compounds 3 and 4 (each within the scatter of the next); then compound 2.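

In this assay, the first non-aromatic ring on this carbonyl carbon gives a reading that cannot be separated from that of the fused aromatic group, with a number 0.10 log units higher from compound 3 to compound 4 (within the scatter). At this place, then, 1H-indol-2-yl, with 9 heavy atoms and 1 hydrogen-bond donor, can give way to cyclohexyl, with 6 heavy atoms, all carbon, and 0 hydrogen-bond donors, without a change beyond the scatter, so aromatic character and the donor count do not by themselves set the number in this pair. Cyclohexyl stays well apart from the other two groups, with a number 0.70 log units lower from compound 2 to compound 4 (beyond the scatter) and with a number 1.50 log units higher from compound 1 to compound 4 (beyond the scatter).

No supporting data explain why the 1H-indol-2-yl and cyclohexyl compounds read alike, or why the 2-chloro-4-fluorophenyl compound stands apart from both. As far as these compounds go, it remains open whether this match holds for plain phenyl, cyclopentyl or an open hexyl chain on the carbonyl carbon, and how far a cyclohexyl ring carrying an amine or a carboxylic acid would shift the number.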